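Vinyl sulfone antiproliferative series: chloro to methoxy exchange

This account rests on a few compounds, and the source may have more. Where it says the series, first, only, none or still open, it means among the compounds named here.

Measured so far in a functional assay on H157 cells (Homo sapiens) for antiproliferative activity, read by trypan blue exclusion; a higher number here means a weaker inhibitor, a lower number a stronger inhibitor:
- compound 1 `COc1ccc(/C=C/S(=O)(=O)Cc2ccc(OC)cc2)cc1`: compound 1 gives > 20000 nM, which is a limit of the assay, not a number.
- compound 2 `COc1ccc(CS(=O)(=O)/C=C/c2ccc(Cl)cc2)cc1`: compound 2 gives 3500 nM.
- compound 3 `COc1ccc(CS(=O)(=O)/C=C/c2ccc(F)cc2Cl)cc1`: compound 3 gives 2500 nM.

Compound 3 holds the lowest of the two numbers, and its gap to compound 2 lies within the scatter. How the cores of compound 2 and compound 3 differ is not broken down here.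

One change is measured: methoxy in place of chloro on an aromatic carbon. It gives an at least 5.7-fold higher number from compound 2 to compound 1 (0.75 log units; beyond the scatter); that size is a lower bound because of the limit of > 20000 nM in this assay, at which 1 of the 3 values shown sits.

The unmeasured compound 4 `COc1ccc(CS(=O)(=O)/C=C/c2ccc(F)cc2OC)cc1` arises from compound 3 by the same kind of change: methoxy in place of chloro on an aromatic carbon. The surroundings are not identical, since in compound 1 the methoxy sits para to a large group, whereas in compound 4 it sits ortho to a large group and meta to a fluoro group.

Resting on the measured step from compound 2 to compound 1, compound 4 is expected to show a step of a 4.8-fold higher number from compound 3 to compound 4 (0.68 log units; beyond the scatter), a weakening of similar direction but less certain size. Compound 4 is thus estimated at 12000 nM in this assay, in the expected range 4000 nM to 35000 nM.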

Compound 4, half-maximal inhibitory concentration: 20000 nM
Compound 4: the middle estimate sits 1.7-fold (0.22 log units) below what was measured; the measured number falls inside the stated range.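

In this assay, methoxy in place of chloro on an aromatic carbon gives an 8.0-fold higher number from compound 3 to compound 4 (0.90 log units; beyond the scatter), so the weakening seen on the core of compound 2 recurs on the core of compound 3, in the same direction and beyond the scatter on both: the same change on two cores in this assay, an at least 5.7-fold higher number (0.75 log units; beyond the scatter) from compound 2 to compound 1 and an 8.0-fold higher number (0.90 log units; beyond the scatter) from compound 3 to compound 4; the limit leaves it open whether they differ. Compound 1 gives > 20000 nM, which is a limit of the assay and not a number, so the sizes of the two steps cannot be set against each other: the limit of > 20000 nM in this assay, at which 1 of the 4 values shown sits. Among these compounds, the two steps support carrying the direction of this change from one core to the other but not its size, and they rest on only two cores, with the methoxy in different surroundings on each.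

Only chloro and methoxy appear at these places, which leaves open whether the weakening follows methoxy itself or the loss of chloro. Going by these compounds, how a hydroxyl, an amine or a longer chain such as ethoxy would behave on the aromatic carbon ortho to a large group also remains open.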